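Dropping the chloro from compound 2: an expected step

The compounds below may be only part of what the source reports. "The series", "measured", "known", "first", "only" and "open" are said of these compounds alone.

Of the compounds shown here, two have been measured in a functional assay on the whole organism for antagonist activity, with Mus musculus as the target; on this read-out higher numbers stand for an effect only at larger amounts of compound and lower numbers for an effect already at smaller amounts. Compound 1 `Cc1nnc(CNC(=O)CN)n1-c1ccc(Cl)cc1C(=O)c1ccccc1F` gives 0.28 mg/kg. Compound 2 `CN(C(=O)CNC(=O)CN)c1ccc(Cl)cc1C(=O)c1ccccc1Cl` gives 3.2 mg/kg, the highest of the two numbers; the nearest is compound 1, whose number is lower by a gap beyond the usual scatter. Going by the values given here, no pair of measured compounds differs in only one place, so no single step can be read from the data directly.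

Compound 3 `CN(C(=O)CNC(=O)CN)c1ccc(Cl)cc1C(=O)c1ccccc1` has not yet been measured. It differs from compound 2 by hydrogen in place of chloro on an aromatic carbon, a change that, cut one bond further out, reads as 2-chlorophenyl to phenyl. Among the compounds with values here, no measured pair reports this change, so its size is unknown. Compound 3 is expected to give a somewhat higher number than compound 2, with a step of a 1.9-fold higher number from compound 2 to compound 3 (0.27 log units; within the scatter) estimated. Compound 3 is therefore estimated at 6 mg/kg, within a range of 2 mg/kg to 20 mg/kg.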

Compound 3, dose for half-maximal effect: 10.9 mg/kg
Estimate against measurement, compound 3: 1.8-fold (0.26 log units) below; the range from low to high includes it.
By their numbers in this assay, from the lowest: compound 1; then compound 2; then compound 3.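

Going by these compounds alone, compound 2 and compound 3 form the only pair here that differs in one place, so the change from 2-chlorophenyl to phenyl can now be read directly in this assay: it gives a 3.4-fold higher number from compound 2 to compound 3 (0.53 log units; beyond the scatter), a modest step. The chloro on this aromatic carbon, ortho to a large group, therefore makes a difference that stands out from the scatter, and with hydrogen in its place, an effect appears only at a larger dose. Nothing in the data at hand accounts for this step.

The compounds shown leave open whether the same change would give a step of similar size on the core of compound 1. They also leave open how a methoxy group or an amine at this place would compare with chloro and hydrogen.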